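The compounds below may be only part of what the source reports. "The series", "measured", "known", "first", "only" and "open" are said of these compounds alone.

Of the compounds shown here, two have been read in a physicochemical assay for lipophilicity, read by HPLC, at pH 7.5 (a lower number here means a more polar compound, a higher number a more lipophilic compound), so far. Compound 1 `CCOc1ccccc1-c1ccc(-c2nc3cnccc3cc2C#N)cc1` gives 3.8 there. Compound 2 `CC[C@@H](Nc1c(C#N)c(-c2ccc(-c3ncccc3C)cc2)nc2cnccc12)C(N)=O` gives 2, the lower of the two numbers; compound 1 lies higher by a margin beyond the scatter. Compound 3 `CC[C@@H](Nc1c(C#N)c(-c2ccc(-c3ccccc3COC)cc2)nc2cnccc12)C(N)=O` differs from compound 2 in a single place: 2-(methoxymethyl)phenyl in place of 3-methylpyridin-2-yl on an aromatic carbon. Among the measured compounds shown here, no measured pair shows an exchange of this kind, so the step of a number 0.60 log units higher from compound 2 to compound 3 (beyond the scatter) is an expectation only, upward and probably beyond the scatter. In this assay compound 3 is expected to give about 2.6, within 2.1 to 3.2.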

Compound 3, distribution coefficient: 2.6
Compound 3: middle estimate and measured number agree at the digits printed; the measured number falls inside the stated range.
By their numbers in this assay, from the lowest: compound 2; then compound 3; then compound 1.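

In this assay, among the compounds shown here, the exchange of 3-methylpyridin-2-yl for 2-(methoxymethyl)phenyl, on an aromatic carbon para to a large group, gives a number 0.60 log units higher from compound 2 to compound 3 (beyond the scatter) and is the first single-place change read. Both groups hold one six-membered aromatic ring and the same counts of hydrogen-bond donors and acceptors, so those counts do not tell them apart. Nothing on hand gives a cause for this step.

The compounds shown do not separate the ring nitrogen leaving from the methoxymethyl group entering. Also open, on these data alone, is where an amine or a carboxylic acid at this position would read in this assay.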